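This account rests on a few compounds, and the source may have more. Where it says the series, first, only, none or still open, it means among the compounds named here.

Measured compounds:
Compound 1 `COc1c(N2CC[C@@H](CN)C2)c(F)cc2c(=O)c(C(=O)O)cn(Cc3ccc(-c4ccccc4)cc3)c12` — 26000 nM in an assay on isolated protein for inhibition of DNA topoisomerase 1 (Homo sapiens), with a stated time of 15 min; a higher number here means a weaker inhibitor, a lower number a stronger inhibitor
Compound 2 `CNC(=O)c1cn(Cc2ccc(-c3ccccc3)cc2)c2c(OC)c(N3CC[C@@H](CN)C3)c(F)cc2c1=O` — 82100 nM
Compound 3 `COc1c(N2CC[C@@H](CN)C2)c(F)cc2c(=O)c(C(=O)NO)cn(Cc3ccc(-c4ccccc4)cc3)c12` — 35900 nM

The three share one core and differ only in the group on the carbonyl carbon. In this assay compound 3 gives the second highest of the three numbers: it sits nearest compound 1, from which it is separated by a 1.4-fold higher number from compound 1 to compound 3 (0.14 log units; within the scatter), a gap within the scatter, and furthest from compound 2, from which it is separated by a 2.3-fold lower number from compound 2 to compound 3 (0.36 log units; beyond the scatter).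

Compound 4 `COc1c(N2CC[C@@H](CN)C2)c(F)cc2c(=O)c(C(N)=O)cn(Cc3ccc(-c4ccccc4)cc3)c12` has not yet been measured. The change from compound 3 to compound 4 is hydrogen in place of hydroxy on an amide-type nitrogen. For the measured compounds named here, no measured pair shows exactly this exchange. The two steps that bear on it both touch the same amide-type nitrogen: a 3.2-fold higher number from compound 1 to compound 2 (0.50 log units; beyond the scatter), a modest weakening, and a 2.3-fold lower number from compound 2 to compound 3 (0.36 log units; beyond the scatter), a modest strengthening back toward compound 1. Together they suggest that this position tolerates small changes with modest effects on the number, in either direction, and that removing the hydroxy should move compound 4 at most by a modest step.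

Compound 4 is therefore expected to lie close to compound 3 and compound 1, with a step of a 1.3-fold higher number from compound 3 to compound 4 (0.10 log units; within the scatter), and the estimated value for compound 4 is 45000 nM, with a range from 20000 nM to 100000 nM.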

Compound 4, half-maximal inhibitory concentration: 184000 nM
The estimate for compound 4 lay 4.1-fold (0.61 log units) below the measured number; measured number above the stated range.
By their numbers in this assay, from the lowest: compounds 1 and 3 (each within the scatter of the next); then compound 2; then compound 4.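

In this assay the bare carbamoyl group proves not to be the small change that the earlier compounds suggested: hydrogen in place of hydroxy on the amide-type nitrogen gives a 5.1-fold higher number from compound 3 to compound 4 (0.71 log units; beyond the scatter) and hydrogen in place of methyl there gives a 2.2-fold higher number from compound 2 to compound 4 (0.35 log units; beyond the scatter), so among these compounds either substituent on that nitrogen gives a lower number than the amide hydrogen alone. Set against the hydroxy on the carbonyl carbon, amino gives a 7.1-fold higher number from compound 1 to compound 4 (0.85 log units; beyond the scatter), the largest of the steps shown at this position, and it leaves compound 4 as the weakest inhibitor of the four. The order therefore does not follow the size of what sits on the nitrogen, and nothing in the data shown accounts for it.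

The compounds shown leave open whether a methoxy group or an ethyl chain on the amide-type nitrogen would also bring the number back down from that of compound 4. They also leave open what a second methyl on that nitrogen would do, since every amide here still keeps at least one hydrogen on it.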